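Replacing trifluoromethyl in a prostaglandin D2 receptor 2 ligand

The source may hold more compounds than are shown below. What is called first, only, known or untested is meant among the compounds shown, and "the series" means these compounds.

Measured so far:
Compound 1 `CN(c1cccc(C#Cc2cc(Cl)ccc2OCC(=O)O)c1)S(C)(=O)=O` in an assay on CHO cells for displacement of a labelled ligand from prostaglandin D2 receptor 2 (Homo sapiens), read by scintillation counting; on this read-out higher numbers stand for weaker inhibition and lower numbers for stronger inhibition: 122 nM
Compound 2 `O=C(O)COc1ccc(Cl)cc1C#Cc1cccc(C(F)(F)F)c1` in this assay: 92 nM

Compound 2 gives the lower of the two numbers, but the step of a 1.3-fold lower number from compound 1 to compound 2 (0.12 log units; within the scatter) lies within the scatter, so the two compounds cannot be placed in order on this read-out. Compound 3 `C[S+]([O-])c1cccc(C#Cc2cc(Cl)ccc2OCC(=O)O)c1` has not yet been tested in this assay. It differs from compound 2 by a group of 3 heavy atoms (1 carbon, 1 oxygen, 1 sulfur; no ring) in place of a group of 4 heavy atoms (1 carbon, 3 fluorine; no ring), on an aromatic carbon. Going by the values given here, the only measured step that bears on this position is a 1.3-fold lower number from compound 1 to compound 2 (0.12 log units; within the scatter), in which a methyl(methylsulfonyl)amino group, one that likewise contains sulfur and oxygen, gave way to trifluoromethyl without a change beyond the scatter. The change to compound 3 runs roughly the other way, back toward a group with sulfur and oxygen, and is the nearest comparison available. On that basis the step is expected to be small, a 1.3-fold higher number from compound 2 to compound 3 (0.12 log units; within the scatter), with no direction beyond the scatter. Compound 3 is therefore estimated at 120 nM in this assay, with a range from 50 nM to 300 nM.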

Compound 3, inhibition constant: 3.2 nM
For compound 3 the middle estimate is 38-fold (1.57 log units) above the measured one; measured number outside the range, below it.
By their numbers in this assay, from the lowest: compound 3; then compounds 2 and 1 (each within the scatter of the next).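

In this assay, the earlier pair gave no sign that this position responds strongly, but the group of 3 heavy atoms (1 carbon, 1 oxygen, 1 sulfur) now gives a 29-fold lower number from compound 2 to compound 3 (1.46 log units; beyond the scatter) and a 38-fold lower number from compound 1 to compound 3 (1.58 log units; beyond the scatter), so the aromatic carbon is sensitive to what it carries. The presence of sulfur and oxygen alone does not account for the outcome, since the methyl(methylsulfonyl)amino group of compound 1 also contains both, yet compound 1 lies within the scatter of compound 2, whose trifluoromethyl contains neither. No supporting measurement is available to explain why this one group stands apart from the other two.

On these data alone, it remains open whether the large step belongs to this exact group or would also appear with a methylthio group or a methylsulfonyl group on the same aromatic carbon, which would show how much the sulfur and its oxygen each contribute. The compounds shown also leave open whether the step would persist if the chlorine or the acetic acid chain of the shared core were replaced, for instance by a fluorine or a propanoic acid chain.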